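Trifluoromethoxy in Place of Trifluoromethyl: Cytotoxicity Outlook

This account rests on a few compounds, and the source may have more. Where it says the series, first, only, none or still open, it means among the compounds named here.

Three compounds with a shared core were tested in an ADME assay on Raji cells (Homo sapiens) for cytotoxicity, with a stated time of 72 h; a higher number here means that more compound is needed for the effect, a lower number that less compound is needed. Compound 1 `COc1ccc(NC(=O)Nc2cc(C)nc3ccccc23)cc1F` reaches only a limit of the assay, > 25000 nM. Compound 2 `Cc1cc(NC(=O)Nc2ccccc2C(F)(F)F)c2ccccc2n1` likewise gives only a limit, > 25000 nM. Compound 3 `Cc1cc(NC(=O)Nc2ccc(F)cc2)c2ccccc2n1` also sits at a limit, > 25000 nM. Among the measured compounds shown here, compound 2 thus stands where every value shown stands, at the limit of > 25000 nM in this assay, at which 3 of the 3 values shown sit; no step between measured compounds can be drawn from these results, and no compound can be called more or less toxic than another.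

Compound 4 `Cc1cc(NC(=O)Nc2ccccc2OC(F)(F)F)c2ccccc2n1` differs from compound 2 by trifluoromethoxy in place of trifluoromethyl on an aromatic carbon. For the measured compounds named here, no measured step gives a direction for this change, and the expected step that the limit leaves unreadable from compound 2 to compound 4 is none beyond the scatter, because the limit of > 25000 nM in this assay, at which 3 of the 3 values shown sit, is where all three measured compounds rest. Compound 4 is therefore estimated at 30000 nM, with a range from 12000 nM to 80000 nM, and it is expected that this assay will most likely again report only a limit rather than a number.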

Compound 4, half-maximal effective concentration: > 25000 nM
Compound 4: only a limit was reported (the forecaster's own chance of this, stated with the estimate: 85%); the middle value does not contradict the limit.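

No step can be read between compound 2 and compound 4, since both give only a limit in this assay: the limit of > 25000 nM in this assay, at which 4 of the 4 values shown sit.

The compounds shown leave open whether any compound with the shared core gives a number rather than a limit in this assay, and so what trifluoromethoxy in place of trifluoromethyl does there.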